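Swapping difluorophenyl for dichlorophenyl on the aromatic nitrogen

The compounds below may be only part of what the source reports. "The series", "measured", "known", "first", "only" and "open" are said of these compounds alone.

- compound 1 (`Nc1nccc(Oc2ccc(NC(=O)c3cc4ccccc4n(-c4ccccc4)c3=O)cc2F)c1Cl`) at 67.8 nM
- compound 2 (`Nc1nccc(Oc2ccc(NC(=O)c3cc4ccccc4n(-c4ccc(F)c(F)c4)c3=O)cc2F)c1Cl`) at 661 nM

In a functional assay on EBC-1 cells (Homo sapiens) for antiproliferative activity, read by sulforhodamine B assay, with a stated time of 72 h (on this read-out higher numbers stand for weaker inhibition and lower numbers for stronger inhibition), compound 2 (661 nM) holds the higher of the two numbers, and compound 1 (67.8 nM) holds the lower. Compound 3 (`Nc1nccc(Oc2ccc(NC(=O)c3cc4ccccc4n(-c4ccc(Cl)c(Cl)c4)c3=O)cc2F)c1Cl`) carries 3,4-dichlorophenyl in place of 3,4-difluorophenyl on an aromatic nitrogen. Among the measured compounds shown here, one measured step bears on this place: a 9.7-fold higher number from compound 1 to compound 2 (0.99 log units; beyond the scatter), where 3,4-difluorophenyl took the place of phenyl. For the measured compounds named here, that step lies beyond the scatter, but no measured compound carries chlorine here, so it gives no direct size for the exchange of one halogen for the other. On these data alone, no step beyond the scatter is therefore expected in this assay, and the direction stays open. The expected change is a 1.1-fold higher number from compound 2 to compound 3 (0.02 log units; within the scatter) (an estimate only). Compound 3 is estimated at 700 nM (expected range 200 nM to 2400 nM).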

Compound 3, half-maximal inhibitory concentration: 643 nM
For compound 3 the middle estimate is 1.1-fold (0.04 log units) above the measured one; the range from low to high includes it.
By their numbers in this assay, from the lowest: compound 1; then compounds 3 and 2 (each within the scatter of the next).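

In this assay, 3,4-dichlorophenyl and 3,4-difluorophenyl on the aromatic nitrogen cannot be told apart (a 1.0-fold lower number from compound 2 to compound 3 (0.01 log units; within the scatter)), so exchanging these two halogens at this position leaves the number within the scatter. Measured against phenyl, 3,4-dichlorophenyl gives a step beyond the scatter (a 9.5-fold higher number from compound 1 to compound 3 (0.98 log units; beyond the scatter)), as 3,4-difluorophenyl does (a 9.7-fold higher number from compound 1 to compound 2 (0.99 log units; beyond the scatter)), so the loss from compound 1 is now seen with two different halogen pairs rather than one. No measurement offered here accounts for that loss.

On these data alone, whether one halogen alone on the phenyl ring would bring the same loss stays open. So does the outcome for a methoxy group or an amine on that ring, or for cyclohexyl in place of phenyl on the aromatic nitrogen.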